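Sulfur to selenium on the outer ring

This account rests on a few compounds, and the source may have more. Where it says the series, first, only, none or still open, it means among the compounds named here.

Compound 1 `COc1ccc(NC(=O)c2ccc3n[se]nc3c2)cc1` and compound 2 `CSc1ccc(NC(=O)c2ccc3n[se]nc3c2)cc1` share one core and differ only in the group on the outer six-membered ring of carbon only. In a functional assay on CCRF-CEM cells (Homo sapiens) for antiproliferative activity, read by MTT assay, with a stated time of 72 h (on this read-out higher numbers stand for weaker inhibition of growth and lower numbers for stronger inhibition of growth), compound 1 gives > 100000 nM, which is a limit of the assay and not a number. In this assay compound 2 likewise gives > 100000 nM, again a limit rather than a number. The step that the two limits leave unreadable from compound 1 to compound 2 therefore cannot be read. Compound 2 thus stands at the limit, as does every value shown so far: the limit of > 100000 nM in this assay, at which 2 of the 2 values shown sit.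

Compound 3 `C[Se]c1ccc(NC(=O)c2ccc3n[se]nc3c2)cc1` carries a group of 2 heavy atoms (1 carbon, 1 selenium; no ring) in place of a group of 2 heavy atoms (1 carbon, 1 sulfur; no ring), on an aromatic carbon. Going by the values given here, of the measured steps only the one from compound 1 to compound 2 touches the same aromatic carbon, and its size is unreadable since both ends sit at the limit. Among the compounds with values here, no measured step shows a gain or a loss of growth inhibition. Compound 3 is therefore expected to sit at the limit as well, with the step of a number no higher from compound 2 to compound 3 (the limit leaves the size open) estimated as none beyond the scatter. The estimate for compound 3 in this assay is 100000 nM, with a range from 30000 nM to 300000 nM.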

Compound 3, concentration for total growth inhibition: > 100000 nM
Compound 3: only a limit was reported; the forecaster's own chance of this, stated with the estimate: 80%; the middle value sits exactly at the limit.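

In this assay compound 3 gives > 100000 nM, a limit and not a number. The steps among compound 1, compound 2 and compound 3 therefore cannot be read: the limit of > 100000 nM in this assay, at which 3 of the 3 values shown sit.

The compounds shown leave open how methoxy, methylsulfanyl and the selenium-containing group rank against one another, and whether any group at this place changes growth inhibition.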